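The source may hold more compounds than are shown below. What is called first, only, known or untested is meant among the compounds shown, and "the series" means these compounds.

Going by the values given here, in a functional assay on MCF7 cells (Homo sapiens) for cytotoxicity, read by MTT assay, with a stated time of 96 h (on this read-out lower numbers stand for stronger inhibition and higher numbers for weaker inhibition), compound 1 `COc1cc(C(=O)c2cn(-c3ccccc3)cc2-c2ccc(N)cc2)cc(OC)c1OC` gives 9 nM, the lowest number among the three compounds measured so far. Compound 2 `COc1ccccc1-n1cc(C(=O)c2cc(OC)c(OC)c(OC)c2)c(-c2ccccc2)c1` gives 150 nM, and compound 3 `COc1cccc(-n2cc(C(=O)c3cc(OC)c(OC)c(OC)c3)c(-c3ccccc3)c2)c1` gives 500 nM. Compound 4 `COc1cc(C(=O)c2cn(-c3ccccc3)cc2-c2ccc(Cl)cc2)cc(OC)c1OC` differs from compound 1 in one place, with chloro in place of amino on an aromatic carbon.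

Among the compounds with values here, no measured step covers this change. Within the data shown here, the only comparison that changes a single place is a 3.3-fold higher number from compound 2 to compound 3 (0.52 log units; beyond the scatter), and it concerns the group on the aromatic nitrogen, so it offers only a rough idea of how far one small change can move the number. Compound 2 and compound 3 also lack the amino group and have higher numbers than compound 1, but they differ from it in a second place as well, so this evidence is weak. A higher number is still expected for the chloro compound, with considerable uncertainty. The expected change is a 5.6-fold higher number from compound 1 to compound 4 (0.74 log units; beyond the scatter). For compound 4 the estimated value is 50 nM, with an expected range from 12 nM to 200 nM.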

Compound 4, half-maximal inhibitory concentration: 290 nM
For compound 4 the middle estimate is 5.8-fold (0.76 log units) below the measured one; measured number outside the range, above it.
By their numbers in this assay, from the lowest: compound 1; then compounds 2, 4 and 3 (each within the scatter of the next, the first and the last beyond it).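

In this assay, going from 4-aminophenyl to 4-chlorophenyl gives a 32-fold higher number from compound 1 to compound 4 (1.51 log units; beyond the scatter), so the group at this position, para to a large group, has a strong hold on the number. Going by these compounds alone, the only earlier single-place step, on the aromatic nitrogen, was smaller: a 3.3-fold higher number from compound 2 to compound 3 (0.52 log units; beyond the scatter). Amino counts one hydrogen-bond donor and one acceptor while chloro counts none, but nothing measured here ties the step to that difference or to any other.

With only amino and chloro shown at this position, it remains open whether a hydroxyl, a methylamino or a dimethylamino group would keep a number as low as that of compound 1. As far as these compounds go, it also remains open whether an amino group here would lower the numbers of compound 2 and compound 3.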